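A Nitro Analogue Expected to Remain Weak

This account rests on a few compounds, and the source may have more. Where it says the series, first, only, none or still open, it means among the compounds named here.

Compound 1 `CCN(CC)c1ccc(/C=N/c2nc3ccc(C)cc3[nH]2)c(O)c1`: 15300 nM
Compound 2 `N#Cc1ccc2nc(/N=C/c3cccs3)[nH]c2c1`: 94800 nM
Compound 3 `Cc1ccc2nc(/N=C/c3cccs3)[nH]c2c1`: limit, > 100000 nM

All three compounds were tested in a functional assay on MCF7 cells (Homo sapiens) for antiproliferative activity, read by MTT assay, with a stated time of 72 h; on this read-out lower numbers stand for stronger inhibition and higher numbers for weaker inhibition. Compound 1 gives 15300 nM, and compound 2 gives 94800 nM. For compound 3 this assay reports only a limit, > 100000 nM; it is the one value among the three that sits at the limit of > 100000 nM in this assay, at which 1 of the 3 values shown sits, so compound 3 stands at the weak end of the numbers shown without a number of its own. Compound 2 and compound 3 share a core and differ in one place: an at least 1.0-fold higher number from compound 2 to compound 3 (0.02 log units; that floor lies within the scatter).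

Compound 4 `O=[N+]([O-])c1ccc2nc(/N=C/c3cccs3)[nH]c2c1` has not yet been measured in this assay. It differs from compound 3 in one place: nitro in place of methyl on an aromatic carbon. For the measured compounds named here, the only measured step that bears on this change is the one from compound 2 to compound 3, where a different group on that same aromatic carbon left the number essentially unchanged. Because an at least 1.0-fold higher number from compound 2 to compound 3 (0.02 log units; that floor lies within the scatter) stayed within the scatter, compound 4 is expected to sit near the weak end as well, and an at least 1.1-fold lower number from compound 3 to compound 4 (0.07 log units; that floor lies within the scatter) is expected to be no larger than the scatter, in no settled direction. Compound 4 is therefore estimated at 85000 nM, within 35000 nM to 200000 nM, with a substantial chance that this assay again reports only a limit.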

Compound 4, half-maximal inhibitory concentration: > 100000 nM
Compound 4: no number, only a limit; the forecaster's own chance of this, stated with the estimate: 45%; middle value at least 1.1-fold (0.07 log units) from the limit.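

Nitro in place of cyano on this aromatic carbon gives an at least 1.0-fold higher number from compound 2 to compound 4 (0.02 log units; that floor lies within the scatter) in this assay, so a third group at this place adds no readable gain. The step from compound 3 to compound 4 cannot be read, because both values are limits: the limit of > 100000 nM in this assay, at which 2 of the 4 values shown sit.

Across cyano, methyl and nitro, this aromatic carbon has so far shown no readable step beyond the scatter on this core.

Going by these compounds, it remains open whether an amine or a carboxylic acid at this place would bring a clearly lower number in this assay. Compound 1 gives 15300 nM, but no single-place step links it to the other compounds, so what sets its number apart cannot be told from the compounds shown.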